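Swapping tert-butyl for trifluoromethyl on the aryl ring

The compounds below may be only part of what the source reports. "The series", "measured", "known", "first", "only" and "open" are said of these compounds alone.

Three compounds have been measured in a functional assay on M21 cells (Homo sapiens) for antiproliferative activity, read by sulforhodamine B assay, with a stated time of 48 h; a higher number here means a weaker inhibitor of growth, a lower number a stronger inhibitor of growth:
Compound 1 `NS(=O)(=O)NCC1CCN(c2cc(-c3ccc(C(F)(F)F)cc3)ncn2)CC1` gives 43100 nM.
Compound 2 `Cc1ccc(-c2cc(N3CCC(CCNS(N)(=O)=O)CC3)ncn2)cc1` gives 57600 nM.
Compound 3 `CC(C)(C)c1ccc(-c2cc(N3CCC(CCNS(N)(=O)=O)CC3)ncn2)cc1` gives 18400 nM.

Compound 3 has the lowest number of the three; its steps to compound 1 and to compound 2 are both beyond the scatter, while compound 1 and compound 2 lie within the scatter of each other. Among the compounds with values here, the one single-point step at the aromatic substituent, a 3.1-fold lower number from compound 2 to compound 3 (0.50 log units; beyond the scatter), is modest. Compound 4 `NS(=O)(=O)NCCC1CCN(c2cc(-c3ccc(C(F)(F)F)cc3)ncn2)CC1` differs from compound 3 by trifluoromethyl in place of tert-butyl on an aromatic carbon. Compound 1 also bears trifluoromethyl and gives a higher number than compound 3, so a modest rise is expected. Compound 4 is expected to show a 1.9-fold higher number from compound 3 to compound 4 (0.28 log units; within the scatter), an estimated 35000 nM with a range from 12000 nM to 100000 nM.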

Compound 4, concentration for 50% growth inhibition: 34800 nM
Estimate against measurement, compound 4: 1.0-fold (0.00 log units) above; measured number inside the range.
By their numbers in this assay, from the lowest: compounds 3, 4, 1 and 2 (each within the scatter of the next, the first and the last beyond it).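

In this assay trifluoromethyl in place of tert-butyl on this aromatic carbon stays within the scatter (a 1.9-fold higher number from compound 3 to compound 4 (0.28 log units; within the scatter)), and so does trifluoromethyl in place of methyl (a 1.7-fold lower number from compound 2 to compound 4 (0.22 log units; within the scatter)), so compound 4 is separated from neither, although methyl and tert-butyl themselves differ beyond the scatter. The (sulfamoylamino)methyl for sulfamoylamino change on the chain also stays within the scatter (a 1.2-fold lower number from compound 1 to compound 4 (0.09 log units; within the scatter)). Nothing available explains these results.

As far as these compounds go, whether a methoxy group or a chlorine atom on the same aromatic carbon would give a number nearer that of compound 3 or compound 2 remains open. So does the effect of an amine in place of the sulfamoylamino group.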